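Methoxy to trifluoromethoxy on the shared core

The compounds below may be only part of what the source reports. "The series", "measured", "known", "first", "only" and "open" are said of these compounds alone.

- compound 1 `COc1ccc(N(C)c2nc(=O)c3cccnc3s2)cc1`: 3400 nM
- compound 2 `CCN(c1ccc(OC)cc1)c1nc(=O)c2cccnc2s1`: 2800 nM

Both values come from a functional assay on cells (Neuron, Rattus norvegicus) for inhibition, read by LDH release, with a stated time of 24 h; on this read-out higher numbers stand for weaker inhibition and lower numbers for stronger inhibition. Going by the values given here, the only measured step is a 1.2-fold lower number from compound 1 to compound 2 (0.08 log units; within the scatter), within the scatter, so compound 1 cannot be told apart from its sole neighbour. Compound 3 `CN(c1ccc(OC(F)(F)F)cc1)c1nc(=O)c2cccnc2s1` differs from the core of compound 1 by trifluoromethyl in place of methyl on an oxygen on an aromatic ring. Among the compounds with values here, that measured step lies at another place on the structure, and no measured step covers this change, so the data give no direction. The expected step is a 1.1-fold lower number from compound 1 to compound 3 (0.05 log units; within the scatter), nothing beyond the scatter. For compound 3 the expected value is 3000 nM, with an estimated range of 1000 nM to 9000 nM.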

Compound 3, half-maximal inhibitory concentration: 2100 nM
Estimate against measurement, compound 3: 1.4-fold (0.15 log units) above; the measured number falls inside the stated range.
By their numbers in this assay, from the lowest: compounds 3, 2 and 1 (each within the scatter of the next).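

At the oxygen on the aromatic ring, replacing methyl with trifluoromethyl gives in this assay the change a 1.6-fold lower number from compound 1 to compound 3 (0.21 log units; within the scatter) and so does not separate the two compounds. Going by these compounds alone, this is the first measured read at this position, and methoxy to trifluoromethoxy leaves the number within the scatter, as the earlier step at the other place did. No measured evidence bears on this result. Open, as far as these compounds go, is how a longer chain or a difluoromethyl group on that oxygen would read, and whether an amine in its place would move the number beyond the scatter.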